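The source may report more compounds than this note shows. Statements on the series, on what has been measured and on what is new or still open speak of the compounds shown alone.

Compound 1 (`COc1ccc(-n2cnnc2-c2cc(OC)c(OC)c(OC)c2)cc1`) gives 3470 nM in a functional assay on COLO 205 cells (Homo sapiens) for inhibition (on this read-out higher numbers stand for weaker inhibition of growth and lower numbers for stronger inhibition of growth), and compound 2 (`COc1cc(-c2nncn2-c2ccc(N(C)C)cc2)cc(OC)c1OC`) gives 87.1 nM on the same read-out. Compound 3 (`COc1ccc(-n2cnnc2-c2cc(OC)c(OC)c(OC)c2)cc1O`) at 1170 nM holds the middle place of the three numbers. Compound 4 (`COc1ccc(-n2cnnc2-c2cc(OC)c(OC)c(OC)c2)cc1F`) differs from compound 3 as follows: fluoro in place of hydroxy on an aromatic carbon (fluoro in place of hydroxy on an aromatic carbon, ortho to a methoxy group and meta to a large group).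

The closest evidence is a 3.0-fold lower number from compound 1 to compound 3 (0.47 log units; beyond the scatter), the modest step that placed the hydroxy on this same carbon. The large step of a 40-fold lower number from compound 1 to compound 2 (1.60 log units; beyond the scatter) concerns a different change, dimethylamino in place of methoxy, and carries little weight here. Among the measured compounds shown here, no measured compound holds a fluoro, so its effect on the number is unknown. Loss of the hydroxy may give back some of the modest step, so a small upward move is expected, possibly no more than the scatter. The expected change is a 1.5-fold higher number from compound 3 to compound 4 (0.19 log units; within the scatter) in the estimate. Compound 4 is estimated at 1800 nM with an expected range of 600 nM to 5000 nM as its limits.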

Compound 4, concentration for 50% growth inhibition: 3980 nM
Compound 4: the middle estimate sits 2.2-fold (0.34 log units) below what was measured, within the range that was stated.
By their numbers in this assay, from the lowest: compound 2; then compound 3; then compounds 1 and 4 (each within the scatter of the next).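

In this assay, the change on this aromatic carbon, ortho to a methoxy group, gives (a 3.4-fold higher number from compound 3 to compound 4 (0.53 log units; beyond the scatter)), so the modest drop in the number seen with hydroxy does not carry over to fluoro. Set against hydrogen on the same carbon, fluoro gives (a 1.1-fold higher number from compound 1 to compound 4 (0.06 log units; within the scatter)), so of the two groups shown here, only hydroxy separates from hydrogen on this read-out. No measurement shown accounts for the difference between hydroxy and fluoro at this position.

Still open, on these data alone, is whether an amine or a chloro on this carbon would track hydroxy or fluoro. Also open, as far as these compounds go, is whether hydroxy here would add anything to the dimethylamino group of compound 2, which stands at 87.1 nM without it.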